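Notes on compound 4: phenyl to pyridin-4-yl

A few compounds are considered here, and "the series" means these few. Any claim that something is new, unique, unknown or untested is made for them only; others in the source may bear on it.

Compound 1 `COc1ccc(NC(=O)CN2CCN(c3nnc(Cc4ccncc4)c4ccccc34)CC2)cc1OC`: 100 nM
Compound 2 `Cc1ccc(NC(=O)CN2CCN(c3nnc(Cc4ccncc4)c4ccccc34)CC2)c(C)c1`: 240 nM
Compound 3 `Cc1ccc(F)cc1NC(=O)CN1CCN(c2nnc(Cc3ccccc3)c3ccccc23)CC1`: 19200 nM

In a functional assay on MDA-MB-231 cells (Homo sapiens) for cytotoxicity, read by MTT assay, with a stated time of 72 h (a higher number here means a weaker inhibitor, a lower number a stronger inhibitor), compound 3 gives 19200 nM, the highest of the three numbers and beyond the scatter from both others. Compound 4 `Cc1ccc(F)cc1NC(=O)CN1CCN(c2nnc(Cc3ccncc3)c3ccccc23)CC1` differs from it as follows: pyridin-4-yl in place of phenyl on a saturated chain carbon bound to an aromatic carbon. This puts pyridin-4-yl in place of phenyl on a saturated chain carbon bound to an aromatic carbon.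

Going by the values given here, no measured step isolates this swap. Among the compounds with values here, the only measured step, a 2.4-fold higher number from compound 1 to compound 2 (0.38 log units; beyond the scatter), concerns the group on the amide-type nitrogen and is modest. Compound 3 differs from compound 1 and compound 2 in that group as well as in phenyl versus pyridin-4-yl, so the comparison is indirect. Compound 4 shares pyridin-4-yl with compound 1 at 100 nM and compound 2 at 240 nM, and its number is therefore expected to lie near theirs, though with wide uncertainty.

The expected change is a large fall, beyond the scatter: a 55-fold lower number from compound 3 to compound 4 (1.74 log units; beyond the scatter). For compound 4 the estimated value is 350 nM, with an expected range of 90 nM to 2500 nM.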

Compound 4, half-maximal inhibitory concentration: 6.4 nM
Beside the measured number, compound 4's estimate is 55-fold (1.74 log units) above it; measured number outside the range, below it.
By their numbers in this assay, from the lowest: compound 4; then compound 1; then compound 2; then compound 3.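

In this assay, the swap of phenyl for pyridin-4-yl on a saturated chain carbon bound to an aromatic carbon can now be read alone: it gives a 3000-fold lower number from compound 3 to compound 4 (3.48 log units; beyond the scatter), with heavy atoms unchanged in number and hydrogen-bond acceptors going from 0 to 1. With pyridin-4-yl held, the group on the amide-type nitrogen also proves able to move the number far more than a 2.4-fold higher number from compound 1 to compound 2 (0.38 log units; beyond the scatter) suggested: 5-fluoro-2-methylphenyl gives a 38-fold lower number from compound 2 to compound 4 (1.57 log units; beyond the scatter) and a 16-fold lower number from compound 1 to compound 4 (1.19 log units; beyond the scatter). Nothing at hand explains either effect.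

Going by these compounds alone, only one pair reads the phenyl to pyridin-4-yl swap, so its size with 2,4-dimethylphenyl or 3,4-dimethoxyphenyl on the amide-type nitrogen remains open. Also open, as far as these compounds go, is whether pyridin-3-yl or pyridin-2-yl in the same place would keep a number this low.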